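Methyl in place of hydrogen: from compound 2 to compound 4

The source may report more compounds than this note shows. Statements on the series, on what has been measured and on what is new or still open speak of the compounds shown alone.

Measured compounds:
compound 1 `CCNc1ccc2c(c1)OC(N)=C(C#N)C2c1cccc([N+](=O)[O-])c1`, 110000000 nM
compound 2 `COc1cc(C2C(C#N)=C(N)Oc3cc(O)ccc32)cc(Br)c1OC`, 130000000 nM
compound 3 `COc1cc(C2C(C#N)=C(N)Oc3c2ccc(O)c3N)cc(Br)c1OC`, 61000000 nM

In a functional assay on T47D cells (Homo sapiens) for activation (on this read-out lower numbers stand for an effect already at smaller amounts and higher numbers for an effect only at larger amounts of compound), compound 2 gives 130000000 nM, the highest of the three numbers. Compound 1 stands within the scatter of it, so the two are not told apart. Compound 3 lies further off: a 2.1-fold lower number from compound 2 to compound 3 (0.33 log units; beyond the scatter), a modest step that comes with amino in place of hydrogen on an aromatic carbon.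

Compound 4 `COc1ccc2c(c1)OC(N)=C(C#N)C2c1cc(Br)c(OC)c(OC)c1` differs from compound 2 in one place: methyl in place of hydrogen on an oxygen on an aromatic ring. For the measured compounds named here, no measured pair shows the same change; the only measured step, from compound 2 to compound 3, alters a different part of the shared core and does not speak to the exchange of hydroxy for methoxy. With nothing to go on, the number for compound 4 is expected to stay close to that of compound 2, with no step beyond the scatter in either direction, so that the expected step is no change at the digits printed from compound 2 to compound 4 (within the scatter). The estimate for compound 4 in this assay is therefore 130000000 nM, with a range from 50000000 nM to 340000000 nM.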

Compound 4, half-maximal effective concentration: 17000000 nM
Compound 4: middle estimate off by 7.6-fold (0.88 log units), on the high side; measured number below the stated range.
By their numbers in this assay, from the lowest: compound 4; then compounds 3, 1 and 2 (each within the scatter of the next, the first and the last beyond it).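

In this assay, methyl in place of hydrogen on an oxygen on an aromatic ring gives a step beyond the scatter (a 7.6-fold lower number from compound 2 to compound 4 (0.88 log units; beyond the scatter)). This shows that the number responds to a change at this oxygen itself, where hydroxy goes to methoxy. The earlier step, amino in place of hydrogen on an aromatic carbon (a 2.1-fold lower number from compound 2 to compound 3 (0.33 log units; beyond the scatter)), concerned a different place on the shared core and did not touch this group. Nothing shown explains why the number moves on this exchange.

The compounds shown leave open whether an ethoxy group or a longer chain on this oxygen would carry the number further in the same direction, and what an amine or a carboxylic acid in place of the hydroxy group would give. They also leave open whether this step would hold with the amino group of compound 3 present.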